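This account rests on a few compounds, and the source may have more. Where it says the series, first, only, none or still open, it means among the compounds named here.

Compound 2 `Cc1c(Cc2ccc(C(F)(F)F)nc2)c[nH]c1C(=O)NC(C)c1cnn(C)c1` is the starting point of this step. Among the measured compounds shown here, in a physicochemical assay for solubility, in simulated intestinal fluid, with a stated time of 5 h, at pH 5.8 (on this read-out higher numbers stand for higher solubility and lower numbers for lower solubility), compound 2 gives 158 ug/mL, the highest of the two plain numbers recorded; its nearest neighbour, compound 1 `Cc1cc(C(C)NC(=O)c2[nH]cc(Cc3ccc(C(F)(F)F)nc3)c2C)no1`, gives 47.8 ug/mL, and the step of a 3.3-fold higher number from compound 1 to compound 2 (0.52 log units; beyond the scatter) is the only measured step available. Compound 3 `Cc1c(C2(c3ccc(C(F)(F)F)nc3)CC2)c[nH]c1C(=O)NC(C)c1nc[nH]n1` reaches only a limit of the assay, > 2000 ug/mL, which is the limit of > 2000 ug/mL in this assay, at which 1 of the 3 values shown sits. Compound 4 `Cc1c(Cc2ccc(C(F)(F)F)nc2)c[nH]c1C(=O)NC(C)c1cn[nH]c1` differs from compound 2 by hydrogen in place of methyl on an aromatic nitrogen. For the measured compounds named here, no measured step covers this exchange, so the earlier step serves only as a scale for what one change can do. Compound 4 is expected to move upward by a 2.0-fold higher number from compound 2 to compound 4 (0.31 log units; beyond the scatter). The value of compound 4 in this assay is estimated at 320 ug/mL, with a range from 130 ug/mL to 800 ug/mL.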

Compound 4, solubility: 81 ug/mL
Compound 4: middle estimate off by 4.0-fold (0.60 log units), on the high side, outside the stated range (below it).
By their numbers in this assay, from the lowest: compounds 1, 4 and 2 (each within the scatter of the next, the first and the last beyond it). At a limit, above all of these: compound 3.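

In this assay, hydrogen in place of methyl on the aromatic nitrogen gives a 2.0-fold lower number from compound 2 to compound 4 (0.29 log units; within the scatter) and so does not separate the two groups at this position. The exchange of the whole group gives a 1.7-fold higher number from compound 1 to compound 4 (0.23 log units; within the scatter) and leaves 1H-pyrazol-4-yl and 5-methyl-1,2-oxazol-3-yl equally unseparated, although compound 2 stands beyond the scatter from compound 1. Nothing given here bears on a reason for this result.

As far as these compounds go, what an ethyl group or a longer chain on this aromatic nitrogen would read stays open, as does the effect of a chain ending in an amine or a carboxylic acid.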